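Notes on the amine substituent, compound 2 to compound 3

The source may hold more compounds than are shown below. What is called first, only, known or untested is meant among the compounds shown, and "the series" means these compounds.

Compound 2 `c1ccc(Cn2nnc3c(NCC4CCCCC4)ncnc32)cc1` holds the higher of the two numbers in an assay on cell membranes for binding affinity to adenosine receptor A1 (Bos taurus), read by radioligand binding; a higher number here means a weaker inhibitor, a lower number a stronger inhibitor: compound 2 gives 2790 nM, while compound 1 `CC1CCCC(Nc2ncnc3c2nnn3Cc2ccccc2)C1` gives 770 nM. Among the measured compounds shown here, the single measured step, a 3.6-fold higher number from compound 1 to compound 2 (0.56 log units; beyond the scatter), also changes the group on the nitrogen on the aromatic ring, so this position moves the number on a modest scale. Compound 3 `CC(Nc1ncnc2c1nnn2Cc1ccccc1)c1ccccc1` carries 1-phenylethyl in place of cyclohexylmethyl on a nitrogen on an aromatic ring. For the measured compounds named here, since compound 2 gives 2790 nM and the only comparable step is a 3.6-fold higher number from compound 1 to compound 2 (0.56 log units; beyond the scatter), a change of similar size is expected, with no firm direction. The estimate for compound 3 is 1500 nM, range 400 nM to 6000 nM, an expected step of a 1.9-fold lower number from compound 2 to compound 3 (0.27 log units; within the scatter).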

Compound 3, inhibition constant: 438 nM
Estimate against measurement, compound 3: 3.4-fold (0.53 log units) above; the measured number falls inside the stated range.
By their numbers in this assay, from the lowest: compounds 3 and 1 (each within the scatter of the next); then compound 2.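

In this assay there is a 6.4-fold lower number from compound 2 to compound 3 (0.80 log units; beyond the scatter) with 1-phenylethyl in place of cyclohexylmethyl, so this position can also move the number down from compound 2. There is also a 1.8-fold lower number from compound 1 to compound 3 (0.25 log units; within the scatter) with 1-phenylethyl in place of 3-methylcyclohexyl, so compound 1 goes against any reading that an aromatic ring is needed for the lower numbers here. No measurement shown explains either step.

Open, from the compounds shown here alone, is whether other groups on this nitrogen, such as cyclopentyl or 2-phenylethyl, would sit with compound 3 and compound 1 or with compound 2.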